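The source may report more compounds than this note shows. Statements on the series, on what has been measured and on what is new or still open speak of the compounds shown alone.

Measured compounds in the series:

Compound 1, `N#CC1=C(N)Oc2c(N)cc3nc4ccccc4nc3c2C12C(=O)N(Cc1cnnn1-c1ccc(F)cc1)c1ccccc12`, gives > 50000 nM, which is a limit of the assay.
Compound 2, `N#CC1=C(N)Oc2c(N)cc3nc4ccccc4nc3c2C12C(=O)N(Cc1cnnn1-c1ccc(Cl)cc1)c1ccccc12`, gives > 50000 nM, again a limit.
Compound 3, `N#CC1=C(N)Oc2c(N)cc3nc4ccccc4nc3c2C12C(=O)N(Cc1cnnn1-c1c(F)cccc1F)c1ccccc12`, gives > 50000 nM, also a limit.

In a functional assay on HepG2 cells (Homo sapiens) for antiproliferative activity, read by MTT assay, with a stated time of 48 h (a lower number here means a stronger inhibitor, a higher number a weaker inhibitor), compound 3 therefore stands only at a limit, not at a number. All three measured compounds share this position, since (the limit of > 50000 nM in this assay, at which 3 of the 3 values shown sit). The measured steps are accordingly unreadable: a step that the two limits leave unreadable from compound 1 to compound 2, a step that the two limits leave unreadable from compound 1 to compound 3 and a step that the two limits leave unreadable from compound 2 to compound 3. Among the compounds with values here, no step in the set has a readable size, so nothing here separates one aryl group on the triazole nitrogen from another.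

The next compound, compound 4, `Cc1ccc(Cl)cc1-n1nncc1CN1C(=O)C2(C(C#N)=C(N)Oc3c(N)cc4nc5ccccc5nc4c32)c2ccccc21`, changes the same position: 5-chloro-2-methylphenyl in place of 2,6-difluorophenyl on an aromatic nitrogen. The three measured steps bear on it only in that every variation of the aryl group on this nitrogen tried so far has left the value at the limit. No direction and no size of step can be read for this assay, and no movement beyond the scatter is expected.

Compound 4 is therefore estimated at 50000 nM in this assay, most likely again reported as a limit. The expected range for compound 4 runs from 15000 nM to 200000 nM. The step this expectation implies is a number no higher from compound 3 to compound 4 (the limit leaves the size open), essentially none.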

Compound 4, half-maximal inhibitory concentration: 17300 nM
Compound 4: middle estimate off by 2.9-fold (0.46 log units), on the high side, and the stated range covers the measured number.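

In this assay the aryl group on the aromatic nitrogen now proves able to move the read-out off the limit, since 5-chloro-2-methylphenyl gives an at least 2.8-fold lower number from compound 3 to compound 4 (0.46 log units; beyond the scatter) and also an at least 2.8-fold lower number from compound 2 to compound 4 (0.46 log units; beyond the scatter) and likewise an at least 2.8-fold lower number from compound 1 to compound 4 (0.46 log units; beyond the scatter) in the same comparison. Chlorine on the aryl ring does not by itself account for this, as compound 2 with 4-chlorophenyl gives > 50000 nM as a limit of the assay. The steps among compounds 1, 2 and 3 still cannot be read, and the true size of each new step also stays open on one side, because the three earlier values share a single limit: the limit of > 50000 nM in this assay, at which 3 of the 4 values shown sit.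

Going by these compounds, it remains open whether the step follows the methyl, the chlorine or the two together, a question that a methylphenyl group without chlorine would address. Also open, on these data alone, is how this assay responds when the aryl ring carries an amine or a carboxylic acid, or when a butyl chain replaces it.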